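The source may report more compounds than this note shows. Statements on the series, on what has been measured and on what is new or still open speak of the compounds shown alone.

In a functional assay on MCF7 cells (Homo sapiens) for antiproliferative activity, read by MTT assay, with a stated time of 72 h (on this read-out higher numbers stand for weaker inhibition of growth and lower numbers for stronger inhibition of growth), the measured compounds are: compound 1 `Clc1cccc(Nc2nc3ncccc3n2Cc2ccccc2)c1` with 43500 nM; compound 2 `O=[N+]([O-])c1cccc(Nc2nc3ncccc3n2Cc2ccccc2)c1` with 24200 nM; compound 3 `Cn1nc(-c2ccnc(Nc3ccc(Cl)cc3)n2)c2ccccc21` with 7830 nM.

Compounds 1 and 2 share a core and differ only by nitro in place of chloro on an aromatic carbon, a change that gave a 1.8-fold lower number from compound 1 to compound 2 (0.25 log units; within the scatter). Compound 3 carries a different core, and the difference between the two cores is not broken down here; its number is lower than that of compound 2 by a margin beyond the scatter, and lower still than that of compound 1.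

Compound 4 `Cn1nc(-c2ccnc(Nc3ccc([N+](=O)[O-])cc3)n2)c2ccccc21` is not yet measured. It differs from compound 3 by nitro in place of chloro on an aromatic carbon. This is the same kind of change as that from compound 1 to compound 2, though not the same: there the nitro sits meta to a large group, here it sits para to a large group.

Because a 1.8-fold lower number from compound 1 to compound 2 (0.25 log units; within the scatter) stayed within the scatter, the expectation for compound 4 is a step of similar small size, a 1.6-fold lower number from compound 3 to compound 4 (0.19 log units; within the scatter). Compound 4 is therefore estimated at 5000 nM, with a likely range from 1500 nM to 15000 nM.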

Compound 4, concentration for 50% growth inhibition: 11800 nM
Compound 4: middle estimate off by 2.4-fold (0.37 log units), on the low side; low and high end bracket the measured number.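

In this assay, nitro in place of chloro on an aromatic carbon gave a 1.5-fold higher number from compound 3 to compound 4 (0.18 log units; within the scatter), a step that is small when taken on its own. Set beside the earlier step, it shows that the change does not carry over unaltered from one core to the other: the same change on two cores in this assay, a 1.8-fold lower number (0.25 log units; within the scatter) from compound 1 to compound 2 and a 1.5-fold higher number (0.18 log units; within the scatter) from compound 3 to compound 4, 2.7-fold (0.43 log units) apart, beyond the scatter of two such steps

Among the compounds shown here, this does not show what lies behind that gap: there are only two pairs, they differ in core, and in compound 4 the nitro stands para to a large group, a place it does not hold in compound 2.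

The compounds shown leave open how other groups in this place, such as an amine, a carboxylic acid or a methoxy group, would behave on either core. They also leave open whether the same swap would keep to either of these two steps on a third core, or with the nitro and chloro moved elsewhere on the ring.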